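The source may report more compounds than this note shows. Statements on the series, on what has been measured and on what is new or still open speak of the compounds shown alone.

Measured compounds, in a physicochemical assay for solubility, read by spectrophotometry, in phosphate buffer, with a stated time of 2 h, at pH 7.4; on this read-out lower numbers stand for lower solubility and higher numbers for higher solubility:
compound 1 `COc1ccc2[nH]c(C(=O)N3CC(=O)N(Cc4ccccc4)[C@@H](COc4ccccc4)C3)cc2c1` gives 12200 nM.
compound 2 `COc1ccc2[nH]c(C(=O)N3CC(=O)N(Cc4ccccc4)[C@@H](CN4CCCC4)C3)cc2c1` gives > 25000 nM, a limit of this assay.
compound 3 `COc1ccc2[nH]c(C(=O)N3CC(=O)N(Cc4ccccc4)[C@@H](Cc4ccccn4)C3)cc2c1` gives > 100000 nM, a limit of this assay.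

Compound 3 thus stands only at a limit, the higher of the two limits shown (the limit of > 100000 nM in this assay, at which 1 of the 3 values shown sits), with compound 2 at the other (the limit of > 25000 nM in this assay, at which 1 of the 3 values shown sits). Compound 4 `COc1ccc2[nH]c(C(=O)N3CC(=O)N(Cc4ccccc4)[C@@H](N4CCc5ccccc54)C3)cc2c1` differs from compound 3 by 2,3-dihydro-1H-indol-1-yl in place of (pyridin-2-yl)methyl on a saturated ring carbon. Among the compounds with values here, the steps reaching compound 3 are an at least 8.1-fold higher number from compound 1 to compound 3 (0.91 log units; beyond the scatter) and a step that the two limits leave unreadable from compound 2 to compound 3, so no measured step sets the size of the change into compound 4. The expectation is a moderate fall, an at least 3.3-fold lower number from compound 3 to compound 4 (0.52 log units; beyond the scatter), with the bulkier group entering. Compound 4 is therefore estimated at 30000 nM, within 8000 nM to 100000 nM.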

Compound 4, solubility: 7000 nM
Estimate against measurement, compound 4: 4.3-fold (0.63 log units) above; the measured number lies below the stated range.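

In this assay, 2,3-dihydro-1H-indol-1-yl on this saturated ring carbon gives the first reading other than that of phenoxymethyl to fall inside the assay's limits, with an at least 14-fold lower number from compound 3 to compound 4 (1.15 log units; beyond the scatter) and an at least 3.5-fold lower number from compound 2 to compound 4 (0.55 log units; beyond the scatter). Against phenoxymethyl, the change gives a 1.7-fold lower number from compound 1 to compound 4 (0.24 log units; within the scatter), so compound 1 and compound 4 cannot be told apart on this read-out. Compound 3 stands only at a limit, so its step is a bound: the limit of > 100000 nM in this assay, at which 1 of the 4 values shown sits.

Compound 2 likewise stands only at a limit: the limit of > 25000 nM in this assay, at which 1 of the 4 values shown sits. On these data alone, how a carboxylic acid or a pyrrolidin-1-yl set directly on this ring carbon would read remains open.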